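The source may report more compounds than this note shows. Statements on the series, on what has been measured and on what is new or still open speak of the compounds shown alone.

Compounds measured so far: compound 1 `COc1ccc(OC(=O)Nc2ccc([Se]C#N)cc2)cc1` and compound 2 `CCOC(=O)Nc1ccc([Se][Se]c2ccc(NC(=O)OCC)cc2)cc1`.

In an ADME assay on BEAS-2B cells (Homo sapiens) for cytotoxicity, read by MTT assay, with a stated time of 72 h (a higher number here means a weaker inhibitor of growth, a lower number a stronger inhibitor of growth), compound 1 gives 48400 nM, the higher of the two numbers. In this assay compound 2 gives 44000 nM, a value within the scatter of that of compound 1, so the two cannot be ordered. Compound 3 `N#C[Se]c1ccc(NC(=O)Oc2ccccc2)cc1` is not yet measured in this assay. It differs from compound 1 by hydrogen in place of methoxy on an aromatic carbon. Among the compounds with values here, no measured pair shows this change, so the expected step, a 1.1-fold lower number from compound 1 to compound 3 (0.03 log units; within the scatter), is small and within the scatter in either direction. Compound 3 is therefore estimated at 45000 nM, with a range from 20000 nM to 110000 nM.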

Compound 3, concentration for total growth inhibition: 38200 nM
Compound 3: middle estimate off by 1.2-fold (0.07 log units), on the high side; the measured number falls inside the stated range.
By their numbers in this assay, from the lowest: compounds 3, 2 and 1 (each within the scatter of the next).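

In this assay, within the data shown here, the exchange of methoxy for hydrogen on this aromatic carbon, para to a large group, gives the first measured step at this position (a 1.3-fold lower number from compound 1 to compound 3 (0.10 log units; within the scatter)). The earlier compounds shown here held no such pair, and this one shows that, in this assay, the methoxy can be absent without a change that stands clear of the scatter. Nothing measured here explains this result.

This reading rests on a single pair. As far as these compounds go, whether an amine, a carboxylic acid or a longer alkoxy chain on the same carbon would give a step beyond the scatter remains open.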